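The compounds below may be only part of what the source reports. "The series", "measured", "known", "first", "only" and "open" are said of these compounds alone.

Measured so far:
Compound 1 `COC(=O)C1=C(C)N=C(C)/C(=C(\O)OC)C1c1cccc(OC)c1` gives 191 nM in a functional assay (muscle tissue) with Cavia porcellus as the target; on this read-out lower numbers stand for an effect already at smaller amounts and higher numbers for an effect only at larger amounts of compound.
Compound 2 `COC(=O)C1=C(C)N=C(C)/C(=C(\O)OC)C1c1cccc(Cl)c1Cl` gives 19.1 nM in this assay.

Among the compounds with values here, compound 2 holds the lower of the two numbers; the only measured step, a 10-fold lower number from compound 1 to compound 2 (1.00 log units; beyond the scatter), separates it from compound 1 by more than the scatter. Compound 3 `COC(=O)C1=C(C)N=C(C)/C(=C(\O)OC)C1c1cccc(I)c1` is not yet measured. It differs from compound 2 by 3-iodophenyl in place of 2,3-dichlorophenyl on a saturated ring carbon. Within the data shown here, no measured step covers this exact exchange, but a 10-fold lower number from compound 1 to compound 2 (1.00 log units; beyond the scatter) concerns the same saturated ring carbon and shows that swapping the aryl group there can shift the number by roughly that amount. Since compound 2 already stands at the lowest number seen, a move to a higher number, smaller than the measured step, is expected for compound 3, as a 2.6-fold higher number from compound 2 to compound 3 (0.42 log units; beyond the scatter). The value of compound 3 in this assay is therefore estimated at 50 nM, with a range from 15 nM to 160 nM.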

Compound 3, half-maximal effective concentration: 41.7 nM
Beside the measured number, compound 3's estimate is 1.2-fold (0.08 log units) above it; low and high end bracket the measured number.
By their numbers in this assay, from the lowest: compound 2; then compound 3; then compound 1.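

In this assay, 3-iodophenyl in place of 2,3-dichlorophenyl on the saturated ring carbon gives a 2.2-fold higher number from compound 2 to compound 3 (0.34 log units; beyond the scatter) and thus costs less than the distance between the two earlier compounds, so an aryl group with one halogen can stay fairly close to the dichlorinated one. Iodo in place of methoxy on an aromatic carbon gives a 4.6-fold lower number from compound 1 to compound 3 (0.66 log units; beyond the scatter) and shows that exchanging a single substituent, with the rest of the aryl group unchanged, already moves the number beyond the scatter, which the earlier step could not show since it also added a second chlorine. Nothing measured here bears on why these numbers differ.

The compounds shown leave open how 3-chlorophenyl would compare, which would separate the kind of halogen from the number of chlorines. They also leave open how an amine, a carboxylic acid or a longer alkoxy chain on the aryl group would read.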